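A few compounds are considered here, and "the series" means these few. Any claim that something is new, unique, unknown or untested is made for them only; others in the source may bear on it.

Compound 2, whose structure is `COc1cccc(CN(C)C(=O)c2cc3ccc(-c4cn[nH]c4)nc3[nH]2)c1`, is the starting point of this step. In an assay on isolated protein for inhibition of Rho-associated protein kinase 1 (Homo sapiens) (a lower number here means a stronger inhibitor, a higher number a weaker inhibitor), compound 2 gives 27 nM. Within the data shown here, compound 1, of structure `COc1cccc(CNC(=O)c2cn(C)c3cc(-c4cn[nH]c4)ccc23)c1`, is the only other compound measured. In this assay compound 1 gives < 1 nM, which is a limit of the assay and not a number: the limit of < 1 nM in this assay, at which 1 of the 2 values shown sits. Among the measured compounds shown here, compound 2 therefore stands as the only compound with a number in this assay; no measured step between two compounds is available to compare with.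

Compound 3 has the structure `COc1cccc(CN(C(=O)c2cc3ccc(-c4cn[nH]c4)nc3[nH]2)C2CC2)c1`. It differs from compound 2 in one place: cyclopropyl in place of methyl on an amide-type nitrogen. For the measured compounds named here, nothing among the measured compounds shows what a change of this kind does in this assay, so the expectation rests on compound 2 alone. The step from compound 2 to compound 3 is estimated as a 1.1-fold higher number from compound 2 to compound 3 (0.05 log units; within the scatter), a shift expected to stay close to the usual scatter with no clear direction. Compound 3 is accordingly expected to give about 30 nM in this assay, within a range from 10 nM to 90 nM.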

Compound 3, half-maximal inhibitory concentration: 33 nM
For compound 3 the middle estimate is 1.1-fold (0.04 log units) below the measured one; the range from low to high includes it.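

In this assay, among these compounds, replacing methyl with cyclopropyl on the amide-type nitrogen gives a 1.2-fold higher number from compound 2 to compound 3 (0.09 log units; within the scatter) and so provides the first measured reading for this position. In this one pair, a group of 3 heavy atoms with a three-membered ring takes the place of a single carbon, and the values of the two compounds stay within the scatter of each other. No measured property bears on why this change leaves the values so close.

From the compounds shown here alone, what a longer chain such as butyl, a chain ending in an amine, or a carboxylic acid on this nitrogen would do remains open, and a single pair gives no trend for larger or differently built groups. Compound 1 carries the amide hydrogen on its nitrogen but differs from compound 2 in more than one place, so it cannot show what the amide hydrogen alone would do with the core of compound 2.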